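Swapping an Aromatic Ring for a Piperidine

The source may hold more compounds than are shown below. What is called first, only, known or untested is meant among the compounds shown, and "the series" means these compounds.

compound 1 `CC(C)(C)C(=O)N1Cc2c(NC(=O)c3cccnc3)n[nH]c2C1(C)C`: 690 nM
compound 2 `CN1CCC(C(=O)N2Cc3c(NC(=O)c4ccsc4)n[nH]c3C2(C)C)CC1`: 140 nM
compound 3 `CC(=O)N1CCC(C(=O)N2Cc3c(NC(=O)c4ccc(F)cc4)n[nH]c3C2(C)C)CC1`: > 10000 nM

In a functional assay on A2780 cells (Homo sapiens) for antiproliferative activity, read by fluorescence, with a stated time of 72 h (a lower number here means a stronger inhibitor, a higher number a weaker inhibitor), compound 1 gives 690 nM, the higher of the two exact numbers. Compound 2 gives 140 nM, a gap beyond the usual scatter. For compound 3, > 10000 nM is a limit of the assay and not a number.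

Compound 4 `CN1CCC(C(=O)Nc2n[nH]c3c2CN(C(=O)C(C)(C)C)C3(C)C)CC1` differs from compound 1 in one place, with 1-methylpiperidin-4-yl in place of pyridin-3-yl on a carbonyl carbon. Going by the values given here, no measured pair shows this swap directly, so any forecast is uncertain. Among the compounds with values here, compound 2, at 140 nM, shows only that a compound carrying 1-methylpiperidin-4-yl elsewhere can remain active. A moderate loss of activity in this assay seems more likely than a gain, with a step beyond the scatter. The expected change is a 2.9-fold higher number from compound 1 to compound 4 (0.46 log units; beyond the scatter). For compound 4, the estimated value is 2000 nM, with an expected range of 400 nM to 9000 nM.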

Compound 4, half-maximal inhibitory concentration: 350 nM
The estimate for compound 4 lay 5.7-fold (0.76 log units) above the measured number, and the stated range ends above it.
By their numbers in this assay, from the lowest: compound 2; then compounds 4 and 1 (each within the scatter of the next). At a limit, above all of these: compound 3.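

On the carbonyl carbon whose other neighbour is an amide-type nitrogen, 1-methylpiperidin-4-yl can take the place of pyridin-3-yl with no clear effect on activity: this assay shows a 2.0-fold lower number from compound 1 to compound 4 (0.29 log units; within the scatter). The earlier compounds shown here differed from each other in more than one place, so they could not isolate this position; this pair does. Here, at least, a six-membered non-aromatic ring serves as well as a six-membered aromatic ring, so activity at this level does not depend on aromaticity at this position in this pair.

Still open, as far as these compounds go, is whether the methyl on the piperidine matters, which a piperidine with a free amine or a carboxylic acid at this position could test. Nothing measured here explains why the two rings give such close numbers.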